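A few compounds are considered here, and "the series" means these few. Any claim that something is new, unique, unknown or untested is made for them only; others in the source may bear on it.

Working notes on the series. Compound 1 `CN(C)C(=O)Cc1sc(NC(=O)c2ccncc2)nc1-c1ccncc1` and compound 2 `O=C(Nc1nc(-c2ccncc2)c(CN2CCCCC2)s1)c1ccncc1` share a core and differ in one place. In an assay on isolated protein for inhibition of Rho-associated protein kinase 2 (Homo sapiens), read by ELISA, with a stated time of 30 min, tested at 10 uM, in the presence of a further agent that is not named here (on this read-out lower numbers stand for less inhibition and higher numbers for more inhibition at the one concentration tested (going by the name of the read-out)), compound 1 gives 38.1%, and compound 2 gives 48.2%, the step being a number 10.1 percentage points higher from compound 1 to compound 2 (beyond the scatter). Among the compounds with values here, compound 2 therefore stands highest of the two numbers measured so far, with compound 1 beyond the scatter below it.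

Compound 3 `CC(C)N(C)c1sc(NC(=O)c2ccncc2)nc1-c1ccncc1` is the next member and is not yet measured. The change from compound 2 is isopropyl(methyl)amino in place of (piperidin-1-yl)methyl on an aromatic carbon. Within the data shown here, the one measured step, a number 10.1 percentage points higher from compound 1 to compound 2 (beyond the scatter), concerns a group on a saturated chain carbon bound to an aromatic carbon, whereas the change to compound 3 sits on an aromatic carbon of the five-membered aromatic ring itself and removes the ring-bearing chain; no measured step addresses that position, so there is no direct precedent. Among the measured compounds shown here, with only one modest step in the set and a change at a different place, the working expectation for compound 3 in this assay is a value of roughly 40%, a step of a number 8.2 percentage points lower from compound 2 to compound 3 (within the scatter) that is not expected to exceed the scatter, and a range of 20% to 60%.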

Compound 3, a percentage reported as inhibition, at one concentration (the size of the read-out at that concentration, not a potency): 32.1%
Compound 3: the middle estimate sits 7.9 percentage points above what was measured, within the range that was stated.
By their numbers in this assay, from the lowest: compounds 3 and 1 (each within the scatter of the next); then compound 2.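

In this assay, putting isopropyl(methyl)amino in place of (piperidin-1-yl)methyl on the aromatic carbon next to the ring sulfur gives a number 16.1 percentage points lower from compound 2 to compound 3 (beyond the scatter), the first sign that the read-out responds to a change made directly at this position. Putting the same group in place of (dimethylcarbamoyl)methyl gives a number 6 percentage points lower from compound 1 to compound 3 (within the scatter), so this step separates neither compound from the other, and among the three groups shown only (piperidin-1-yl)methyl stands clear of the other two. No measurement at hand accounts for either step.

The step from compound 2 to compound 3 changes the ring, the size of the group and the atom bound to the aromatic carbon all at once, so the compounds shown leave open which of these goes with the difference. A piperidin-1-yl group bound directly to that aromatic carbon, or an open-chain (dimethylamino)methyl group, would separate the ring from the link, and a morpholin-4-ylmethyl group would show whether a second hetero atom in the ring matters.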